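The source may report more compounds than this note shows. Statements on the series, on what has been measured and on what is new or still open speak of the compounds shown alone.

Compound 1 `O=C1C(=O)N(CCCCCn2cc(COc3cc(=O)oc4ccccc34)nn2)c2ccc(Cl)cc21` is a chloro-bearing member of this small series. In a functional assay on THP-1 cells (Homo sapiens) for inhibition, read by sulforhodamine B assay, with a stated time of 48 h, tested at 50 uM (on this read-out higher numbers stand for more inhibition of growth at the one concentration tested and lower numbers for less inhibition of growth), compound 1 gives 59%. Compound 2 `O=C1C(=O)N(CCCCCn2cc(COc3cc(=O)oc4ccccc34)nn2)c2ccc([N+](=O)[O-])cc21` carries the change nitro in place of chloro on an aromatic carbon on the same core, and in this assay compound 2 gives 37%. This single exchange produced a number 22 percentage points lower from compound 1 to compound 2 (beyond the scatter), a drop that lies beyond the scatter of the method but is modest in size.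

Compound 3 `O=C1C(=O)N(CCCn2cc(COc3cc(=O)oc4ccccc34)nn2)c2ccc(Cl)cc21` keeps the chloro substituent but differs from compound 1 in the linker; the difference between the two cores is not broken down here. In this assay compound 3 gives 78%, the highest of the three numbers, and its steps to compound 1 and to compound 2 are both beyond the scatter.

Compound 4 `O=C1C(=O)N(CCCn2cc(COc3cc(=O)oc4ccccc34)nn2)c2ccc([N+](=O)[O-])cc21` has not been measured. It stands to compound 3 as compound 2 stands to compound 1: the change is nitro in place of chloro on an aromatic carbon, the same change as before, at the same place on the ring. Because the earlier exchange gave a number 22 percentage points lower from compound 1 to compound 2 (beyond the scatter), the expected step from compound 3 to compound 4 is estimated as a number 21 percentage points lower from compound 3 to compound 4 (beyond the scatter), resting on that one measured pair alone. Compound 4 is therefore expected to give about 57% in this assay, with a likely range from 42% to 72%.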

Compound 4, percent growth inhibition at one concentration: 60%
Beside the measured number, compound 4's estimate is 3 percentage points below it; measured number inside the range.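

In this assay, nitro in place of chloro on an aromatic carbon again gave a lower number on the second core, with a number 18 percentage points lower from compound 3 to compound 4 (beyond the scatter), and the two pairs agree on this change: the same change on two cores in this assay, a number 22 percentage points lower (beyond the scatter) from compound 1 to compound 2 and a number 18 percentage points lower (beyond the scatter) from compound 3 to compound 4, 4 percentage points apart, within the scatter of two such steps Across these two cores, then, the exchange carried over in both direction and size, so the step measured on the core of compound 1 described what happened on the core of compound 3. Within the data shown here, this rests on only two pairs, read in one cell line at one concentration, and it shows neither why nitro gives the lower number nor that the same step would appear on a core outside this series.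

The compounds shown hold only chloro and nitro on that aromatic carbon, leaving open whether a group such as fluoro, methoxy or an amine would give a number nearer that of the chloro compounds or that of the nitro compounds. They also leave open whether the step would stay the same with a longer chain in the linker, or with a carboxylic acid placed elsewhere on the shared core.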